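Swapping the aryl amide substituent on a shared core

A few compounds are considered here, and "the series" means these few. Any claim that something is new, unique, unknown or untested is made for them only; others in the source may bear on it.

Compound 3 `C=CC1=C(C(=O)Nc2ccccc2OC)C(c2ccc(OC)cc2)OC1` carries a 2-methoxyphenyl group on its amide nitrogen. In a functional assay on HeLa cells (Homo sapiens) for cytotoxicity, read by MTT assay, with a stated time of 24 h (a lower number here means a stronger inhibitor, a higher number a weaker inhibitor), compound 3 reaches only the limit of the measurement, > 100000 nM, which is a limit rather than a number; this is the limit (the limit of > 100000 nM in this assay, at which 1 of the 3 values shown sits). Compound 1 `C=CC1=C(C(=O)NCCC)C(c2ccc(OC)cc2)OC1` gives 14000 nM in this assay, and compound 2 `C=CC1=C(C(=O)NCc2ccc(C)cc2)C(c2ccc(OC)cc2)OC1` gives 15900 nM, with a 1.1-fold higher number from compound 1 to compound 2 (0.06 log units; within the scatter). Against these two, compound 3 falls off: an at least 7.1-fold higher number from compound 1 to compound 3 (0.85 log units; beyond the scatter) and an at least 6.2-fold higher number from compound 2 to compound 3 (0.79 log units; beyond the scatter).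

Compound 4 `C=CC1=C(C(=O)Nc2ccc(C)cc2)C(c2ccc(OC)cc2)OC1` differs from compound 3 by 4-methylphenyl in place of 2-methoxyphenyl on an amide-type nitrogen. Among the measured compounds shown here, no measured step tests an aryl amide against another aryl amide; the two measured steps onto compound 3 only show that the 2-methoxyphenyl amide is weaker than both alkyl-type amides, and 4-methylphenyl keeps the aryl amide arrangement while dropping the methoxy. The expected step of an at least 1.6-fold lower number from compound 3 to compound 4 (0.22 log units; that floor lies within the scatter) is therefore a modest move toward a stronger inhibitor, but with a real chance that compound 4 again sits at the limit. Compound 4 is estimated at 60000 nM in this assay, within 15000 nM to 200000 nM.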

Compound 4, half-maximal inhibitory concentration: > 100000 nM
Compound 4: no number, only a limit; the forecaster's own chance of this, stated with the estimate: 45%; middle value at least 1.6-fold (0.22 log units) from the limit.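

In this assay compound 4 gives > 100000 nM, which is a limit and not a number. The 4-methylphenyl amide falls off as well, with an at least 6.2-fold higher number from compound 2 to compound 4 (0.79 log units; beyond the scatter) and an at least 7.1-fold higher number from compound 1 to compound 4 (0.85 log units; beyond the scatter), so the loss against the propyl and 4-methylbenzyl amides is no longer tied to the 2-methoxyphenyl group. Both aryl amides give only limits, so the step between them cannot be read: the limit of > 100000 nM in this assay, at which 2 of the 4 values shown sit.

The compounds shown leave open whether any aryl amide on this nitrogen gives a number in this assay, for instance a phenyl ring carrying an amine or a carboxylic acid. Also open, on these data alone, is whether a longer chain on the amide, or a methoxy group in place of the methyl on the benzyl group of compound 2, would hold a measurable value.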